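A few compounds are considered here, and "the series" means these few. Any claim that something is new, unique, unknown or untested is made for them only; others in the source may bear on it.

Within the data shown here, in a functional assay on MT4 cells (Homo sapiens) for cytotoxicity (on this read-out lower numbers stand for higher toxicity in this test and higher numbers for lower toxicity in this test), compound 2 (`CC(=O)CSc1nc(O)c(C)c(Cc2cccc3ccccc23)n1`) gives 85000 nM, the only actual number in this small set and the lowest reading of the three. Compound 1 (`Cc1ccc(C(=O)CSc2nc(O)c(C)c(Cc3cccc4ccccc34)n2)cc1`) reads >= 251000 nM, which is a limit and not a number. Compound 3 (`Cc1c(O)nc(SCC(=O)c2ccc(Cl)cc2)nc1Cc1cccc2ccccc12`) reads >= 198000 nM, which is also a limit.

Compound 4 (`COC(=O)CSc1nc(O)c(C)c(Cc2cccc3ccccc23)n1`) differs from compound 2 in one place, with methoxy in place of methyl on a carbonyl carbon, (methoxy in place of methyl on a carbonyl carbon). Acetyl thus becomes methoxycarbonyl.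

Among the measured compounds shown here, two measured steps concern the same carbonyl carbon. Methyl in place of 4-methylphenyl gave an at least 2.9-fold lower number from compound 1 to compound 2 (0.47 log units; beyond the scatter), and 4-chlorophenyl in place of methyl gave an at least 2.3-fold higher number from compound 2 to compound 3 (0.36 log units; beyond the scatter). Going by these compounds, both are beyond the scatter, but both rest on limits, so their true sizes remain open. For the measured compounds named here, both also exchange methyl for a substituted phenyl or the reverse, and no measured step exchanges methyl for methoxy. No ring enters in the new change, so the expectation stays near compound 2 at 85000 nM, with no step beyond the scatter expected in this assay. The expected change is a 1.2-fold higher number from compound 2 to compound 4 (0.07 log units; within the scatter). The estimate for compound 4 is 100000 nM, with an expected range of 35000 nM to 280000 nM.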

Compound 4, half-maximal cytotoxic concentration: >= 296000 nM
Compound 4: only a limit was reported (the forecaster's own chance of this, stated with the estimate: 30%); at least 2.9-fold (0.47 log units) between middle value and limit.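

In this assay the change from acetyl to methoxycarbonyl gives an at least 3.4-fold higher number from compound 2 to compound 4 (0.54 log units; beyond the scatter), so a step beyond the scatter at this carbonyl carbon does not require a ring to enter, as it did with the substituted phenyl groups. Going by these compounds, compound 4 reads >= 296000 nM, which is a limit and not a number, and the size of this step therefore stays open: the limit of >= 296000 nM in this assay, at which 1 of the 4 values shown sits. Every group shown on this carbonyl carbon in place of methyl, whether methoxy, 4-methylphenyl or 4-chlorophenyl, now goes with a higher reading, while the values of compounds 1, 3 and 4 are all limits and the steps among them cannot be read.

On these data alone, it remains open whether the lower reading of compound 2 belongs to methyl alone, which an amine on this carbonyl carbon, the corresponding carboxylic acid or a longer chain such as ethyl would test. Also open, as far as these compounds go, is how far compounds 1, 3 and 4 lie beyond their limits, so no order among the three can be stated.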